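The source may report more compounds than this note shows. Statements on the series, on what has been measured and on what is new or still open speak of the compounds shown alone.

Two compounds from this series share a core and were both tested in an assay on isolated protein for binding affinity to adenosine receptor A1 (Bos taurus); on this read-out higher numbers stand for weaker inhibition and lower numbers for stronger inhibition. Compound 1 `FC(F)(F)c1ccccc1Cn1nnc2c(NC3CCCCC3)nc(-c3ccccc3)nc21` gives 6800000 nM in this assay, a number so large that it points to hardly any binding at all. Compound 2 `CCCCCCNc1nc(-c2ccccc2)nc2c1nnn2Cc1ccccc1` gives 13200000 nM in this assay. The gap between these two numbers lies within the usual scatter of the measurement, so the two compounds cannot be told apart on this read-out; because the two also differ in more than one place, their pair says nothing about any single change.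

Compound 3 `Clc1ccccc1Cn1nnc2c(NC3CCCCC3)nc(-c3ccccc3)nc21` has not been measured yet. It differs from compound 1 in one spot only: chloro in place of trifluoromethyl on an aromatic carbon, on an aromatic carbon of a six-membered aromatic ring of carbon only. For the measured compounds named here, no measured pair in this set shows what such a swap does here. Given that compound 1 gives 6800000 nM, compound 3 is expected to stay at about the same very weak level, with a step from compound 1 to compound 3 of a 1.1-fold lower number from compound 1 to compound 3 (0.05 log units; within the scatter), which is no change beyond the scatter. Compound 3 is therefore estimated at 6000000 nM, in a range from 1500000 nM to 25000000 nM.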

Compound 3, inhibition constant: 34000000 nM
Compound 3: middle estimate off by 5.7-fold (0.75 log units), on the low side; measured number outside the range, above it.
By their numbers in this assay, from the lowest: compounds 1 and 2 (each within the scatter of the next); then compound 3.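

In this assay, for the compounds shown here, replacing trifluoromethyl with chloro on an aromatic carbon ortho to a large group gives a 5.0-fold higher number from compound 1 to compound 3 (0.70 log units; beyond the scatter), the first single-change reading in this set. It shows that this read-out can respond to the group at this position, even among compounds with very large numbers: the two groups are not interchangeable here, and compound 1 has the lower number of this pair. Still, this is one pair on one core, and compound 3 at 34000000 nM points to very weak binding, so the step separates two poor binders rather than revealing a route to strong binding, and nothing measured here accounts for the difference.

The compounds shown leave open how fluoro, methyl, methoxy or an amine at this position would compare with trifluoromethyl and chloro, and whether any of them would bring the number down substantially. They also leave open whether the same swap would give a similar step if the cyclohexylamine part of compound 1 were replaced by a longer chain or a carboxylic acid.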